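The compounds below may be only part of what the source reports. "The series", "measured", "known", "first", "only" and "open" are said of these compounds alone.

Working notes on the series. Compound 1 `CC(C)COC(=O)Nc1ccc([Se]C#N)cc1` is tested in a physicochemical assay, with a stated time of 180 min, tested at 0.5 mg/mL (a higher number here means more inhibition at the concentration tested (going by the name of the read-out), a lower number less inhibition), and gives 27.1%. Among the compounds with values here, compound 2 `CCCCOC(=O)Nc1ccc([Se][Se]c2ccc(NC(=O)OCCCC)cc2)cc1` gives 36.1% in this assay; no step is worked out for this pair, and the two numbers sit within the scatter of each other, so compound 1 does not stand apart from compound 2. Compound 3 `N#C[Se]c1ccc(NC(=O)OCc2ccccc2)cc1` is not yet measured. It differs from compound 1 in one place: phenyl in place of isopropyl on a saturated chain carbon bound to an oxygen next to a carbonyl group. Nothing measured in the series bears on this change, so no step beyond the scatter is expected in this assay, and the expected step is a number 2.9 percentage points higher from compound 1 to compound 3 (within the scatter). Compound 3 is expected to give 30% in this assay, within 15% to 45%.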

Compound 3, a percentage reported as inhibition, at one concentration (the size of the read-out at that concentration, not a potency): 3.7%
Compound 3: middle estimate off by 26.3 percentage points, on the high side; measured number below the stated range.
By their numbers in this assay, from the lowest: compound 3; then compounds 1 and 2 (each within the scatter of the next).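

In this assay, phenyl in place of isopropyl on a saturated chain carbon bound to an oxygen next to a carbonyl group gives a number 23.4 percentage points lower from compound 1 to compound 3 (beyond the scatter), a modest step but beyond the scatter. Within the data shown here, this position is therefore not indifferent to the group it carries, which the earlier compounds could not show. Nothing on hand accounts for the step.

On these data alone, it remains open whether the step belongs to the aromatic ring as such. A cyclohexyl group or a longer chain in this place would bear on that.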